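Methoxy for chloro on a weakly inhibiting core

This account rests on a few compounds, and the source may have more. Where it says the series, first, only, none or still open, it means among the compounds named here.

Compound 1, `O=c1oc(-c2ccccc2I)nc2ccc(Cl)cc12`, gives 27300 nM in an assay on isolated protein for inhibition of complement C1r subcomponent (Homo sapiens); a higher number here means a weaker inhibitor, a lower number a stronger inhibitor.
Compound 2, `O=c1oc(-c2ccccc2I)nc2cc(Cl)c(Cl)cc12`, gives no number but a limit, > 62500 nM, in this assay.

Among the measured compounds shown here, compound 1 thus stands as the only measured number in this assay; the other result is a limit. For the measured compounds named here, the one measured step, an at least 2.2-fold higher number from compound 1 to compound 2 (0.35 log units; beyond the scatter), rests on (the limit of > 62500 nM in this assay, at which 1 of the 2 values shown sits), so its true size is not known beyond being at least modest.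

Compound 3, `COc1ccc2nc(-c3ccccc3I)oc(=O)c2c1`, differs from compound 1 by methoxy in place of chloro on an aromatic carbon. Going by the values given here, no measured step exchanges chloro for methoxy; the step from compound 1 to compound 2 concerns a second chloro entering elsewhere on the core and bears on this change only loosely, showing that the core tolerates little variation without the number rising. The expectation for this assay is therefore a step of no clear direction beyond the scatter, with some risk of a weaker number. Compound 3 is estimated to give 35000 nM, within 12000 nM to 100000 nM, which would mean a step of a 1.3-fold higher number from compound 1 to compound 3 (0.11 log units; within the scatter).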

Compound 3, half-maximal inhibitory concentration: > 62500 nM
Compound 3: no number, only a limit; the forecaster's own chance of this, stated with the estimate: 30%; middle value at least 1.7-fold (0.25 log units) from the limit.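

In this assay, among the compounds shown here, methoxy in place of chloro on this aromatic carbon gives an at least 2.2-fold higher number from compound 1 to compound 3 (0.35 log units; beyond the scatter), so this exchange at the chloro of compound 1 also moves the number upward, which the earlier compounds did not show. For the compounds shown here, until now, the only step had been a second chloro entering elsewhere on the core; here the existing chloro itself is exchanged, and the change beyond the scatter is in the same direction. Compound 3 gives only a limit, > 62500 nM, and as with compound 2, the size of its step cannot be read, so neither compound can be placed against the other, and the true loss may be modest or much larger: the limit of > 62500 nM in this assay, at which 2 of the 3 values shown sit.

Going by these compounds alone, compound 1 gives 27300 nM, the only measured value so far, and still open is whether any group on this aromatic carbon can bring the number down from there. A hydrogen, a fluoro, a methyl or an amine in place of the chloro would show whether compound 1 already lies near the best this position allows, or whether chloro and methoxy are both poor choices there.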